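Toxicity of an amide series: from cyanophenyl to methylphenyl

This account rests on a few compounds, and the source may have more. Where it says the series, first, only, none or still open, it means among the compounds named here.

Compound 1 `Cn1c(-c2cccc(C#N)c2)cnc1NC(=O)c1ncc[nH]1`: > 50000 nM
Compound 2 `COc1ccc(-c2cnc(NC(=O)c3cccc([N+](=O)[O-])c3)n2C)cc1`: > 100000 nM
Compound 3 `COc1ccc(-c2cnc(NC(=O)c3cccc(C#N)c3)n2C)cc1`: > 100000 nM

In a toxicity assay on THP-1 cells (Homo sapiens) for inhibition (on this read-out lower numbers stand for higher toxicity in this test and higher numbers for lower toxicity in this test), compound 1 reaches only a limit, > 50000 nM. Compound 2 likewise reaches only a limit, > 100000 nM. Compound 3 also reaches only a limit, > 100000 nM. Two of the three values sit at the limit of > 100000 nM in this assay, at which 2 of the 3 values shown sit, and one at the limit of > 50000 nM in this assay, at which 1 of the 3 values shown sits, so every number here is a limit and none is a measured value. Among the measured compounds shown here, the single measured step, a step that the two limits leave unreadable from compound 2 to compound 3, is itself unreadable and gives no sense of size or direction. Compound 4 `COc1ccc(-c2cnc(NC(=O)c3ccccc3C)n2C)cc1` differs from compound 3 by 2-methylphenyl in place of 3-cyanophenyl on a carbonyl carbon. With no readable step to draw on, compound 4 is expected to show no step beyond the scatter, a number no higher from compound 3 to compound 4 (the limit leaves the size open). Compound 4 is estimated at 100000 nM, within 30000 nM to 300000 nM.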

Compound 4, half-maximal cytotoxic concentration: > 100000 nM
Compound 4: only a limit was reported; the forecaster's own chance of this, stated with the estimate: 85%; the middle value lies on the limit itself.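

In this assay compound 4 gives only a limit, > 100000 nM. No step can be read between compound 3 and compound 4, both being limits. The compounds shown leave open whether any of the four has a measurable half-maximal cytotoxic concentration in this assay.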